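The source may hold more compounds than are shown below. What is called first, only, known or untested is meant among the compounds shown, and "the series" means these compounds.

Measured so far:
Compound 1 (`COc1cc(C(=O)c2sc(-c3ccc(Br)cc3)cc2N)cc(OC)c1OC`): 100 nM
Compound 2 (`COc1cc(C(=O)c2sc(-c3ccc([N+](=O)[O-])cc3)cc2N)cc(OC)c1OC`): 100 nM
Compound 3 (`COc1cc(C(=O)c2sc(-c3ccccc3Cl)cc2N)cc(OC)c1OC`): 20 nM

All three values come from a functional assay on L1210 cells (Mus musculus) for antiproliferative activity (on this read-out higher numbers stand for weaker inhibition and lower numbers for stronger inhibition), and share one core. Compound 3 gives 20 nM as the lowest number of the three, and so the strongest inhibition in this small set. Two measured steps lead to it: one shows a 5.0-fold lower number from compound 1 to compound 3 (0.70 log units; beyond the scatter) and the other shows a 5.0-fold lower number from compound 2 to compound 3 (0.70 log units; beyond the scatter) as a step of the same modest size. The remaining step shows no change at the digits printed from compound 1 to compound 2 (within the scatter) and so separates nothing.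

Compound 4 (`COc1ccc(-c2cc(N)c(C(=O)c3cc(OC)c(OC)c(OC)c3)s2)cc1`) is not yet measured. It differs from compound 3 by 4-methoxyphenyl in place of 2-chlorophenyl on an aromatic carbon in the form of 4-methoxyphenyl in place of 2-chlorophenyl on an aromatic carbon. The entering group resembles 4-bromophenyl in compound 1 at 100 nM and 4-nitrophenyl in compound 2 at 100 nM in where its substituent sits. Those two steps, read in reverse, are therefore the best guide, and a modest rise in this assay is expected. Among the compounds with values here, no methoxy compound has been measured, so the size remains uncertain. The expected change is a 3.5-fold higher number from compound 3 to compound 4 (0.54 log units; beyond the scatter) in the direction of weaker inhibition. Compound 4 is estimated at 70 nM with an expected range from 20 nM to 250 nM in this read-out.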

Compound 4, half-maximal inhibitory concentration: 45 nM
Compound 4: middle estimate off by 1.6-fold (0.19 log units), on the high side, within the range that was stated.
By their numbers in this assay, from the lowest: compound 3; then compound 4; then compounds 1 and 2 (each within the scatter of the next).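

With 4-methoxyphenyl on this aromatic carbon next to the ring sulfur, the tie between the 4-bromophenyl and 4-nitrophenyl compounds no longer describes every 4-substituted phenyl group in this assay: methoxy in place of bromo gives a 2.2-fold lower number from compound 1 to compound 4 (0.35 log units; beyond the scatter) and methoxy in place of nitro gives a 2.2-fold lower number from compound 2 to compound 4 (0.35 log units; beyond the scatter), so the group carried by this phenyl ring can shift the number. The 2-chlorophenyl group still holds the lowest number among the four compounds, and the change to 4-methoxyphenyl gives a 2.3-fold higher number from compound 3 to compound 4 (0.35 log units; beyond the scatter), a smaller step than those separating compound 3 from the bromo and nitro compounds. The data at hand give no explanation for any of these differences.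

The compounds shown leave open whether the chlorine itself or its place in the 2-chlorophenyl group sets compound 3 apart, as they offer no direct comparison of the same group at two places on the phenyl ring. They also leave open how a dimethylamino group or a carboxylic acid on that ring would compare with methoxy, bromo and nitro.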